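The source may report more compounds than this note shows. Statements on the series, on what has been measured and on what is new or still open speak of the compounds shown alone.

Compound 1 `Cc1ccc(S(=O)(=O)c2nc3ccccc3nc2N2CCCC2)cc1` in a functional assay on HCT-116 cells (Homo sapiens) for cytotoxicity, read by MTT assay, with a stated time of 72 h (on this read-out higher numbers stand for weaker inhibition and lower numbers for stronger inhibition), gives > 50000 nM.
Compound 2 `COc1ccc(S(=O)(=O)c2nc3ccccc3nc2N2CCCC2)cc1` in this assay gives > 50000 nM.
Compound 3 `Cc1ccc(S(=O)(=O)c2nc3ccccc3nc2N2CCC(O)CC2)cc1` in this assay gives 5440 nM.

Compound 1 and compound 2 each return a limit of the assay rather than a number. Their structures differ only by methoxy in place of methyl on an aromatic carbon. Since both values are limits, the step that the two limits leave unreadable from compound 1 to compound 2 cannot be read from them; the evidence of the limit of > 50000 nM in this assay, at which 2 of the 3 values shown sit, shows where both sit.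

Compound 3 carries a different core, differing from compound 1 by 4-hydroxypiperidin-1-yl in place of pyrrolidin-1-yl on an aromatic carbon. Here the step of an at least 9.1-fold lower number from compound 1 to compound 3 (0.96 log units; beyond the scatter) is the first to yield a number on this read-out, and it is the only number among the three values given.

Compound 4 `COc1ccc(S(=O)(=O)c2nc3ccccc3nc2N2CCC(O)CC2)cc1` has not yet been measured. It stands to compound 3 as compound 2 stands to compound 1: the change is methoxy in place of methyl on an aromatic carbon, made at the same place, so it is the same change as before, only on the core of compound 3. That earlier change left no readable step, so it gives no direction for the present one. The expectation therefore rests on compound 3 alone, whose value 5440 nM is a number. The step from compound 3 to compound 4 is expected to be small, about a 1.1-fold higher number from compound 3 to compound 4 (0.04 log units; within the scatter), with room either way. Compound 4 is thus estimated at 6000 nM in this assay, expected to lie between 2500 nM and 15000 nM.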

Compound 4, half-maximal inhibitory concentration: 4690 nM
The estimate for compound 4 lay 1.3-fold (0.11 log units) above the measured number; measured number inside the range.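

In this assay, the change from 4-methylphenyl to 4-methoxyphenyl gives a 1.2-fold lower number from compound 3 to compound 4 (0.06 log units; within the scatter), so this swap leaves compound 3 and compound 4 indistinguishable on this read-out. The other change, 4-hydroxypiperidin-1-yl in place of pyrrolidin-1-yl, gives an at least 10-fold lower number from compound 2 to compound 4 (1.02 log units; beyond the scatter), and it points the same way whether the aromatic ring carries methyl or methoxy: the same change on two cores in this assay, an at least 9.1-fold lower number (0.96 log units; beyond the scatter) from compound 1 to compound 3 and an at least 10-fold lower number (1.02 log units; beyond the scatter) from compound 2 to compound 4; the limit leaves it open whether they differ This shows that the direction of the ring change carries over between these two cores, but not how large the step really is on either one, and the step from compound 1 to compound 2 cannot be read at all, because compound 1 and compound 2 both stand at a limit of the assay rather than at a number: the limit of > 50000 nM in this assay, at which 2 of the 4 values shown sit.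

The compounds shown leave open whether the lower numbers go with the hydroxyl group or with the change of ring itself, a question that a plain piperidin-1-yl group or a 4-aminopiperidin-1-yl group could help to settle. Also open, on these data alone, is how a group other than methyl or methoxy, such as a chlorine atom or a carboxylic acid, would read on the core of compound 3.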